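Methyl in Place of Chloro: Expected Cytotoxicity of Compound 4

The source may hold more compounds than are shown below. What is called first, only, known or untested is meant among the compounds shown, and "the series" means these compounds.

Compound 1 `Cc1cc(Oc2ccccc2OCCn2ccc(=O)[nH]c2=O)c(Cl)c2cc(C#N)ccc12` gives only a limit in a toxicity assay on MT2 cells (Homo sapiens) for cytotoxicity, read by MTT assay (on this read-out lower numbers stand for higher toxicity in this test and higher numbers for lower toxicity in this test), namely > 100000 nM.
Compound 2 `Cc1cc(Oc2ccccc2OCCn2ccc(=O)[nH]c2=O)c(C)c2cc(C#N)ccc12` likewise gives only a limit in this assay, namely > 100000 nM.
Within the data shown here, compound 3 `N#Cc1ccc2c(F)cc(Oc3ccc(F)cc3OCCn3ccc(=O)[nH]c3=O)c(Cl)c2c1` is the one compound with an actual number in this assay, giving 28000 nM.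

Compound 1 and compound 2 differ by one change, (methyl in place of chloro on an aromatic carbon). Both values are limits, so the step that the two limits leave unreadable from compound 1 to compound 2 cannot be read, because the limit of > 100000 nM in this assay, at which 2 of the 3 values shown sit, holds both of them. Compound 3 differs from compound 1 in more than one place, and the difference between the two cores is not broken down here.

Compound 4 `Cc1c(Oc2ccc(F)cc2OCCn2ccc(=O)[nH]c2=O)cc(F)c2ccc(C#N)cc12` is not yet measured. It differs from compound 3 by methyl in place of chloro on an aromatic carbon. Among the measured compounds shown here, this is the same kind of change as the one from compound 1 to compound 2, but not the same: in compound 4 the methyl sits para to a fluoro group, while in compound 2 it sits para to a methyl group.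

The step of a 1.1-fold higher number from compound 3 to compound 4 (0.03 log units; within the scatter) is expected to be small, because a step that the two limits leave unreadable from compound 1 to compound 2 stayed hidden under the same limit for both compounds and gave no sign of a large shift. In this assay compound 4 is therefore estimated at 30000 nM, with a range expected from 10000 nM to 100000 nM.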

Compound 4, half-maximal cytotoxic concentration: > 100000 nM
Compound 4: only a limit was reported; the forecaster's own chance of this, stated with the estimate: 35%; at least 3.3-fold (0.52 log units) between middle value and limit.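

In this assay, methyl in place of chloro on an aromatic carbon gives an at least 3.5-fold higher number from compound 3 to compound 4 (0.55 log units; beyond the scatter), a step beyond the usual scatter, so on this core the change goes with lower toxicity in this test. The value of compound 4 is a limit, > 100000 nM, which means that the step has a known minimum but no known full size. The same change on the core of compound 1 gives a step that cannot be read, so this result does not show whether the change acts alike on both cores, and the reason the comparison fails is that both members of that pair sit at one shared limit: the limit of > 100000 nM in this assay, at which 3 of the 4 values shown sit.

Compound 3 is the only compound here with an actual number, 28000 nM, so the compounds shown leave open how much of the toxicity seen in this test depends on the chloro group and how much on the rest of that core. Also open, going by these compounds, is how other groups on this aromatic carbon, such as a methoxy group, an amine or a carboxylic acid, would read in this assay on either core.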